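Sulfanyl-linked ring in place of oxygen-linked ring on the core

The source may hold more compounds than are shown below. What is called first, only, known or untested is meant among the compounds shown, and "the series" means these compounds.

Compound 1 `CC(C)[C@H](NC(=O)COc1cccc2ccccc12)C(=O)N[C@@H](CC(=O)O)C(=O)COc1cc(C(F)(F)F)n(C)n1` is the reference point of the series. In a functional assay on Jurkat cells (Homo sapiens) for inhibition (a higher number here means a weaker inhibitor, a lower number a stronger inhibitor), compound 1 gives 46000 nM, the lowest of the two numbers in hand. Compound 2 `COC(=O)c1cc(OCC(=O)[C@H](CC(=O)O)NC(=O)[C@@H](NC(=O)COc2cccc3ccccc23)C(C)C)no1` gives 71000 nM in this assay, and a 1.5-fold higher number from compound 1 to compound 2 (0.19 log units; within the scatter), so the two compounds are not separated here. For compound 3 `CC(C)[C@H](NC(=O)COc1cccc2ccccc12)C(=O)N[C@@H](CC(=O)O)C(=O)CSc1nncn1C` this assay reports only a limit, > 200000 nM.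

Counted from the structures, the change from compound 1 to compound 4 `CC(C)[C@H](NC(=O)COc1cccc2ccccc12)C(=O)N[C@@H](CC(=O)O)C(=O)CSc1nc2ccccc2o1` is (1,3-benzoxazol-2-yl)sulfanyl in place of (1-methyl-5-(trifluoromethyl)-1H-pyrazol-3-yl)oxy on a saturated chain carbon bound to a carbonyl carbon. Within the data shown here, two measured steps bear on it: an at least 4.3-fold higher number from compound 1 to compound 3 (0.63 log units; beyond the scatter) and an at least 2.8-fold higher number from compound 2 to compound 3 (0.44 log units; beyond the scatter). Both put a sulfanyl-linked five-membered ring in place of an oxygen-linked one on a saturated chain carbon bound to a carbonyl carbon, and both are cut off by the limit of > 200000 nM in this assay, at which 1 of the 3 values shown sits, so their full size is not known. Among the measured compounds shown here, the change to compound 4 is of the same kind, except that the entering group adds one six-membered aromatic ring of carbon only, and no measured pair shows what that addition does on its own.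

The expected step is therefore a 2.8-fold higher number from compound 1 to compound 4 (0.45 log units; beyond the scatter), a weakening beyond the scatter, taken from the direction of an at least 4.3-fold higher number from compound 1 to compound 3 (0.63 log units; beyond the scatter). Compound 4 is expected at 130000 nM, between 45000 nM and 400000 nM, with a real chance that this assay returns only a limit.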

Compound 4, half-maximal inhibitory concentration: > 200000 nM
Compound 4 gave a limit, no number; the forecaster's own chance of this, stated with the estimate: 35%; middle value at least 1.5-fold (0.18 log units) from the limit.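

In this assay compound 4 gives only a limit, > 200000 nM. The readable steps, an at least 4.3-fold higher number from compound 1 to compound 4 (0.63 log units; beyond the scatter) and an at least 2.8-fold higher number from compound 2 to compound 4 (0.44 log units; beyond the scatter), run the same way as the steps into compound 3, so the weakening on moving from an oxygen-linked ring to a sulfanyl-linked ring on a saturated chain carbon bound to a carbonyl carbon now holds for two entering groups, (4-methyl-4H-1,2,4-triazol-3-yl)sulfanyl and (1,3-benzoxazol-2-yl)sulfanyl, and no compound shown goes against it. The step between compound 3 and compound 4 cannot be read, and the two readable steps give only a minimum size: the limit of > 200000 nM in this assay, at which 2 of the 4 values shown sit.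

The compounds shown leave open whether the loss follows the sulfur link or the ring it carries, as every change to a sulfanyl group here also replaces the ring. A (1,3-benzoxazol-2-yl)oxy group in this place, or an amine link carrying the 1-methyl-5-(trifluoromethyl)-1H-pyrazol-3-yl ring, would test the link with the ring held fixed.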